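This account rests on a few compounds, and the source may have more. Where it says the series, first, only, none or still open, it means among the compounds named here.

Working notes on the thiourea series. Going by the values given here, compound 1 `Cc1cc(CN/C(S)=N/Cc2ccc(NS(C)(=O)=O)cc2)c(COC(=O)C(C)(C)C)cc1C` gives 70000 nM in a functional assay for inhibition of Vanilloid receptor (Rattus norvegicus) (on this read-out higher numbers stand for weaker inhibition and lower numbers for stronger inhibition), and is the weaker of the two measured members. Compound 2 `CCCCCOc1cc(C(C)(C)C)ccc1C/N=C(\S)NCc1ccc(NS(C)(=O)=O)cc1` gives 70 nM in this assay, the lowest of the two numbers shown; the nearest other number, that of compound 1, lies far higher, a gap well beyond the usual scatter. Among the compounds with values here, the two compounds differ in several places at once, so no single step is set out between them; their two values only show that compound 2 is strongly the better inhibitor.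

Compound 3 `COCOc1cc(C(C)(C)C)ccc1C/N=C(\S)NCc1ccc(NS(C)(=O)=O)cc1` is the next member to be measured. Its difference from compound 2 is methoxy in place of butyl on a saturated chain carbon bound to an oxygen on an aromatic ring — in words, methoxy in place of butyl on a saturated chain carbon bound to an oxygen on an aromatic ring, which shortens the pentyloxy chain to methoxymethoxy and brings in one hydrogen-bond acceptor.

Within the data shown here, no measured step covers this change. Compound 3 is expected to sit near compound 2 or somewhat weaker, a step from compound 2 to compound 3 of a 4.3-fold higher number from compound 2 to compound 3 (0.63 log units; beyond the scatter). The estimate for compound 3 is 300 nM, with a range from 70 nM to 1500 nM.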

Compound 3, half-maximal inhibitory concentration: 500 nM
Beside the measured number, compound 3's estimate is 1.7-fold (0.22 log units) below it, and the stated range covers the measured number.
By their numbers in this assay, from the lowest: compound 2; then compound 3; then compound 1.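

Compound 3 gives the series its first change in one place: in this assay, going from pentyloxy to methoxymethoxy gives a 7.1-fold higher number from compound 2 to compound 3 (0.85 log units; beyond the scatter) on the read-out. This shows that inhibition responds to what is carried on a saturated chain carbon bound to an oxygen on an aromatic ring, with butyl giving the lower number of the two groups compared here. The step is modest, however, and compound 3 at 500 nM still shows that methoxy in place of butyl leaves a measurable inhibitor, while no data bear on why the number rises, and the shorter chain and the added oxygen enter together in this one step.

An all-carbon chain such as ethoxy or propoxy, set against a longer chain such as octyloxy, would separate the effect of chain length from that of the chain oxygen. Going by these compounds, whether a chain ending in an amine or a carboxylic acid is tolerated at this position also remains open.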